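A Second Methyl for Hydrogen, at a Different Place

The source may report more compounds than this note shows. Statements on the series, on what has been measured and on what is new or still open speak of the compounds shown alone.

Of the compounds shown here, three have been tested in a functional assay on CHO cells for agonist activity at Free fatty acid receptor 1 (Homo sapiens), read by FLIPR, tested at 100 nM; on this read-out lower numbers stand for a weaker effect and higher numbers for a stronger effect at the one concentration tested. Compound 1 `CCc1ccc(OCC(=O)Nc2ccc(OCC(=O)O)c(F)c2)cc1` gives 14.6%. Compound 2 `CC(C)c1ccc(OCC(=O)Nc2ccc(OCC(=O)O)c(F)c2)cc1` differs from it by methyl in place of hydrogen on a saturated chain carbon bound to an aromatic carbon and a saturated chain carbon and gives 11.8%, so the step of a number 2.8 percentage points lower from compound 1 to compound 2 (within the scatter) is small. Compound 3 `CC(C)(C)c1cccc(OCC(=O)Nc2ccc(OCC(=O)O)c(F)c2)c1` gives 40.2%, the highest of the three numbers; how its core differs from the core of compound 1 is not broken down here.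

Compound 4 `CC(Oc1cccc(C(C)(C)C)c1)C(=O)Nc1ccc(OCC(=O)O)c(F)c1` is not yet measured. It differs from compound 3 by methyl in place of hydrogen on a saturated chain carbon bound to a carbonyl carbon and an oxygen on an aromatic ring. In both pairs a methyl replaces hydrogen on a saturated chain carbon, but in compound 2 that carbon is bound to an aromatic carbon and a saturated chain carbon, whereas in compound 4 it is bound to a carbonyl carbon and an oxygen on an aromatic ring, so the two changes are the same kind of change rather than the same change.

Within the data shown here, the only guide is the step of a number 2.8 percentage points lower from compound 1 to compound 2 (within the scatter), which lay within the scatter, so the expected step from compound 3 is a number 2.2 percentage points lower from compound 3 to compound 4 (within the scatter). Compound 4 is therefore expected to give about 38%, within a range from 20% to 56%.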

Compound 4, a percentage reported as activity, at one concentration (the size of the read-out at that concentration, not a potency): 32.8%
The estimate for compound 4 lay 5.2 percentage points above the measured number; the range from low to high includes it.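

In this assay, placing a methyl on the saturated chain carbon bound to a carbonyl carbon and an oxygen on an aromatic ring gives a number 7.4 percentage points lower from compound 3 to compound 4 (within the scatter), a step too small to separate from ordinary repeat variation. Set beside the earlier methyl-for-hydrogen step, the new step tells the same story: the same change on two cores in this assay, a number 2.8 percentage points lower (within the scatter) from compound 1 to compound 2 and a number 7.4 percentage points lower (within the scatter) from compound 3 to compound 4, 4.6 percentage points apart, within the scatter of two such steps. Among these compounds, this shows only that in these two pairs a methyl for a hydrogen left the read-out within the scatter; it does not show that the same change carries from one core to another, since the methyl sits on a different carbon in each pair, and two pairs at one concentration say nothing about potency.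

The compounds shown leave open what a methyl on that same carbon would do on the core of compound 1. They also leave open whether a longer chain such as ethyl, or a hydroxyl group, on that carbon would keep the read-out of compound 3 or move it beyond the scatter.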